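Pyrazoline acetamides: amine swap at the chain carbon

The compounds below may be only part of what the source reports. "The series", "measured", "known", "first", "only" and "open" are said of these compounds alone.

Measured in a functional assay on MGC-803 cells (Homo sapiens) for cytotoxicity, read by MTT assay, with a stated time of 48 h; on this read-out lower numbers stand for stronger inhibition and higher numbers for weaker inhibition:
- compound 1 `CC1=NN(S(=O)(=O)c2ccc(C)cc2)C(c2cc(Br)ccc2O)C1`: 30700 nM
- compound 2 `CC(=O)Oc1ccccc1C1CC(C)=NN1C(=O)CN1CCC(O)CC1`: 3510 nM
- compound 3 `CCNCC(=O)N1N=C(c2cc3ccccc3oc2=O)CC1c1ccccc1`: 26600 nM

Compound 3 gives the second highest of the three numbers in this assay. Its nearest neighbour is compound 1, whose number is within the scatter of that of compound 3, so no order between the two is claimed. Compound 2 sits furthest away, with a number beyond the scatter lower than that of compound 3. Within the data shown here, compound 2 carries a different core and a different substituent set, and no single-point step between any pair of the measured compounds is available, so what drives the gap cannot be read from these three.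

Compound 4 `CN1CCN(CC(=O)N2N=C(c3cc4ccccc4oc3=O)CC2c2ccccc2)CC1` is the next compound and differs from compound 3 in one place: 4-methylpiperazin-1-yl in place of ethylamino on a saturated chain carbon bound to a carbonyl carbon. Among the measured compounds shown here, no measured pair shows this change, so there is no step to lean on. The expectation is a step of no more than the usual scatter, in either direction, for a 1.3-fold lower number from compound 3 to compound 4 (0.12 log units; within the scatter). Compound 4 is therefore estimated at 20000 nM in this assay, with a range from 7000 nM to 60000 nM.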

Compound 4, half-maximal inhibitory concentration: 46100 nM
Beside the measured number, compound 4's estimate is 2.3-fold (0.36 log units) below it; low and high end bracket the measured number.
By their numbers in this assay, from the lowest: compound 2; then compounds 3, 1 and 4 (each within the scatter of the next).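

In this assay, among these compounds, the first step that can be read at a single place is a 1.7-fold higher number from compound 3 to compound 4 (0.24 log units; within the scatter) and it stays inside the scatter, so no order between the two compounds is claimed. At the saturated chain carbon bound to a carbonyl carbon, the open ethylamino group, with 3 heavy atoms, no ring and 1 hydrogen-bond donor, gives way to 4-methylpiperazin-1-yl, with 7 heavy atoms, a six-membered non-aromatic ring and 0 hydrogen-bond donors, and the read-out does not separate the two. The earlier compounds could show nothing about this position, and no measurement here accounts for the outcome of this swap.

The compounds shown leave open whether other groups on this carbon, such as a morpholine ring, a dimethylamino group or a carboxylic acid, would also stay within the scatter of compound 3 or move beyond it. A single step also cannot tell whether a longer chain between the carbonyl and the amine, or the same amine swap on another core, would give the same picture.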